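Flipping one ring stereocentre in a modest alpha-1 binder

The source may hold more compounds than are shown below. What is called first, only, known or untested is meant among the compounds shown, and "the series" means these compounds.

Of the compounds shown here, three have been measured in an assay on isolated protein for binding affinity to Adrenergic receptor alpha-1 (Rattus norvegicus), read by radioligand binding, in the presence of a further agent that is not named here; a lower number here means a stronger inhibitor, a higher number a weaker inhibitor. Compound 1 `Cc1ccc2c(c1)C=C(CC1CN=C(N)O1)CC2` gives 251 nM, and compound 2 `Clc1cccc2c1CC(CC1CN=CN1)CC2` gives 316 nM. Compound 3 `C[C@@]1(C[C@@H]2CN=CN2)CCc2ccccc2C1` gives 1000 nM, the highest of the three numbers: compound 2 is the nearest to it and compound 1 the furthest, and both gaps lie beyond the usual scatter, so compound 3 is the weakest of the three.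

Compound 4 `C[C@@]1(C[C@H]2CN=CN2)CCc2ccccc2C1` is the compound not yet measured. Compared with compound 3, (the two compounds have the same atoms and bonds and differ only in configuration as drawn: 1 of 2 stereo elements differ; a stereocentre at a saturated ring carbon is drawn R in compound 3 and S in compound 4). Among the compounds with values here, no pair of measured compounds here differs in a single change, so there is no measured step to lean on for the size of this one. A change in configuration alone can leave a number almost untouched or shift it in either direction, and the present data cannot tell which. The step from compound 3 to compound 4 is therefore expected to be small, a 1.4-fold lower number from compound 3 to compound 4 (0.15 log units; within the scatter), with a wide range around it. Compound 4 is estimated at 700 nM, between 150 nM and 3000 nM.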

Compound 4, inhibition constant: 2000 nM
The estimate for compound 4 lay 2.9-fold (0.46 log units) below the measured number; measured number inside the range.
By their numbers in this assay, from the lowest: compounds 1 and 2 (each within the scatter of the next); then compounds 3 and 4 (each within the scatter of the next).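

Within the data shown here, this pair gives the first single-change comparison in the set, and in this assay switching the saturated ring carbon from R to S gives a 2.0-fold higher number from compound 3 to compound 4 (0.30 log units; within the scatter). At this stereocentre, the numbers therefore do not separate the two configurations, and no preference for either can be claimed. The step can be read as the result of configuration alone because nothing else separates the two structures: the fact that compounds 3 and 4 differ only in the configuration as drawn

Going by these compounds, the second stereo element is the same in both compounds, so the effect of changing it remains open. The compounds shown also do not tell whether the step would stay this size if the methyl group were replaced by an ethyl group or a hydroxyl group.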